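The compounds below may be only part of what the source reports. "The series", "measured", "known", "first", "only" and "open" are said of these compounds alone.

Measured compounds:
- Compound 1, `CS(=O)(=O)c1ccc2nc(-c3ccc(-c4ccc(Cl)cc4)cc3)[nH]c2c1`: in an assay on isolated protein for inhibition of acyl-CoA desaturase 1 (Rattus norvegicus) (on this read-out higher numbers stand for weaker inhibition and lower numbers for stronger inhibition), compound 1 gives > 20000 nM, which is a limit of the assay rather than a number.
- Compound 2, `CS(=O)(=O)c1ccc2nc(-c3ccc(-c4ccccc4O)cc3)[nH]c2c1`: in this assay compound 2 gives 336 nM.

Compound 2 thus carries the only actual number shown; the other value, (the limit of > 20000 nM in this assay, at which 1 of the 2 values shown sits), is a limit. Among the compounds with values here, the single measured step, an at least 59-fold lower number from compound 1 to compound 2 (1.77 log units; beyond the scatter), accompanied the arrival of a 2-hydroxyphenyl group in place of a 4-chlorophenyl group.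

Compound 3, `CS(=O)(=O)c1ccc2nc(-c3ccc(-c4ccsc4)cc3)[nH]c2c1`, differs from compound 2 in one place: thiophen-3-yl in place of 2-hydroxyphenyl on an aromatic carbon. This change gives up the very group whose arrival went with the large measured step, and the entering thiophen-3-yl brings no hydrogen-bond donor. Within the data shown here, the one measured step bears on this position and was large, so a sizeable move back toward weaker inhibition is expected for compound 3, though not necessarily all the way to the limit, as the entering group also differs from the 4-chlorophenyl of compound 1.

For compound 3 the expected value in this assay is 3000 nM, within 700 nM to 20000 nM, meaning an expected step of an 8.9-fold higher number from compound 2 to compound 3 (0.95 log units; beyond the scatter).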

Compound 3, half-maximal inhibitory concentration: 104 nM
For compound 3 the middle estimate is 29-fold (1.46 log units) above the measured one, outside the stated range (below it).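

Replacing 2-hydroxyphenyl with thiophen-3-yl did not undo the earlier gain. this assay instead shows a 3.2-fold lower number from compound 2 to compound 3 (0.51 log units; beyond the scatter), so among the compounds shown, a hydrogen-bond donor on this group is not needed for inhibition, and a five-membered aromatic ring with one sulfur atom is accepted here as well as a six-membered ring of carbon only. Compound 3 also differs sharply from the other end of the series, with an at least 190-fold lower number from compound 1 to compound 3 (2.28 log units; beyond the scatter), which means that two quite different groups both outperform 4-chlorophenyl at this position. That step can be stated only as a minimum because compound 1 carries a limit of the assay rather than a number: the limit of > 20000 nM in this assay, at which 1 of the 3 values shown sits.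

The compounds shown leave open whether the chlorine itself or its place on the ring sets compound 1 apart, a question that plain phenyl, 2-chlorophenyl and 4-hydroxyphenyl groups could help to separate. They also leave open whether the sulfur atom matters in compound 3 or whether another five-membered ring, such as furan-3-yl or thiophen-2-yl, would do as well.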